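The source may hold more compounds than are shown below. What is called first, only, known or untested is meant among the compounds shown, and "the series" means these compounds.

Measured so far:
compound 1, `CCCCCCCCCCCCCCNc1nc(SCc2ccc(C(F)(F)F)cc2)nc2ccccc12`: > 50000 nM
compound 2, `O=[N+]([O-])c1cccc(Nc2nc(SCc3ccc(C(F)(F)F)cc3)nc3ccccc23)c1`: 31500 nM

Both were run in a functional assay on MDA-MB-231 cells (Homo sapiens) for cytotoxicity, read by MTT assay, with a stated time of 72 h; a higher number here means a weaker inhibitor, a lower number a stronger inhibitor. For compound 1 the figure is a limit of the assay and not a number; one of the two values shown sits there, (the limit of > 50000 nM in this assay, at which 1 of the 2 values shown sits). Compound 2 gives the only actual number shown, 31500 nM, so it is the sole point of reference for the next step.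

Compound 3, `COc1ccc(Nc2nc(SCc3ccc(C(F)(F)F)cc3)nc3ccccc23)cc1OC`, has not yet been measured in this assay. It carries 3,4-dimethoxyphenyl in place of 3-nitrophenyl on a nitrogen on an aromatic ring. Within the data shown here, no step between two measured compounds is available to calibrate this change, and the two values shown do not allow any ordering of compound 1 against compound 2 beyond what they show. The expected step is small and in no clear direction, a 1.3-fold lower number from compound 2 to compound 3 (0.10 log units; within the scatter), within or close to the scatter. Compound 3 is expected to give about 25000 nM, in the range 8000 nM to 80000 nM, with a real chance that only a limit is returned.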

Compound 3, half-maximal inhibitory concentration: 18900 nM
Compound 3: the middle estimate sits 1.3-fold (0.12 log units) above what was measured; low and high end bracket the measured number.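

In this assay, among these compounds, 3,4-dimethoxyphenyl in place of 3-nitrophenyl on a nitrogen on an aromatic ring gives a 1.7-fold lower number from compound 2 to compound 3 (0.22 log units; within the scatter), the first step that can be read between two actual numbers. At this position, the exchange therefore produces no change that can be separated from the usual scatter, even though one substituted six-membered aromatic ring of carbon only replaces another with a different substitution. Nothing measured here bears on the cause of this step, and a single pair gives no trend for the position.

As far as these compounds go, whether a different group on this nitrogen, such as an unsubstituted phenyl, a pyridine ring or a phenyl carrying a carboxylic acid or an amine, would move the number beyond the scatter in this assay remains open. Compound 1 stands at a limit of the assay and not at a number, so no step involving it can be read: the limit of > 50000 nM in this assay, at which 1 of the 3 values shown sits.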